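A sec-butyl ester estimated from its ester neighbours

The source may hold more compounds than are shown below. What is called first, only, known or untested is meant among the compounds shown, and "the series" means these compounds.

In a physicochemical assay for lipophilicity (on this read-out lower numbers stand for lower lipophilicity and higher numbers for higher lipophilicity), compound 2 `CCOC(=O)CNC(=O)C(CSc1ccc([N+](=O)[O-])cc1[N+](=O)[O-])NC(=O)CCC(NC(=O)OCc1ccccc1)C(=O)O` gives 1.82. Compound 1 `COC(=O)CNC(=O)C(CSc1ccc([N+](=O)[O-])cc1[N+](=O)[O-])NC(=O)CCC(NC(=O)OCc1ccccc1)C(=O)O` carries hydrogen in place of methyl on a saturated chain carbon bound to an oxygen next to a carbonyl group and in this assay compound 1 gives 1.32, a step of a number 0.50 log units lower from compound 2 to compound 1 (beyond the scatter). Compound 3 `CCCC(C)OC(=O)CNC(=O)C(CSc1ccc([N+](=O)[O-])cc1[N+](=O)[O-])NC(=O)CCC(NC(=O)OCc1ccccc1)C(=O)O` differs from compound 2 by propyl in place of hydrogen on a saturated chain carbon bound to an oxygen next to a carbonyl group and a saturated chain carbon and in this assay compound 3 gives 2.8, a step of a number 0.98 log units higher from compound 2 to compound 3 (beyond the scatter) and, against compound 1, of a number 1.48 log units higher from compound 1 to compound 3 (beyond the scatter). Compound 4 `CCC(C)OC(=O)CNC(=O)C(CSc1ccc([N+](=O)[O-])cc1[N+](=O)[O-])NC(=O)CCC(NC(=O)OCc1ccccc1)C(=O)O` has not been measured; it differs from compound 3 by hydrogen in place of methyl on a saturated chain carbon, three bonds along the chain from an oxygen next to a carbonyl group. This is the same kind of change as that leading from compound 2 to compound 1, but the carbon lies three bonds along the chain from the oxygen rather than bound to it. For compound 4 the step in this assay is expected at a number 0.50 log units lower from compound 3 to compound 4 (beyond the scatter), because the same kind of change gave a number 0.50 log units lower from compound 2 to compound 1 (beyond the scatter). Compound 4 is therefore estimated at 2.3, expected to lie between 1.9 and 2.7.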

Compound 4, partition coefficient: 2.72
Beside the measured number, compound 4's estimate is 0.42 log units below it; measured number outside the range, above it.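

In this assay hydrogen in place of methyl, three bonds along the chain from an oxygen next to a carbonyl group, gives a number 0.08 log units lower from compound 3 to compound 4 (within the scatter) while the same kind of change on the carbon bound to that oxygen gave a number 0.50 log units lower from compound 2 to compound 1 (beyond the scatter) and so, in these two pairs, the step did not carry over from one ester to the other. The sec-butyl ester still stands apart from the shorter esters, with a number 0.90 log units higher from compound 2 to compound 4 (beyond the scatter) and a number 1.40 log units higher from compound 1 to compound 4 (beyond the scatter) in the same assay. Each version of the change rests on a single pair, which shows nothing about other cores, and no measurement here accounts for the difference.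

Going by these compounds, whether a longer chain such as hexyl or a cyclohexyl ester would follow compound 3 or compound 4 remains open. So does the effect of an amine at the end of the ester chain.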